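The source may report more compounds than this note shows. Statements on the series, on what has been measured and on what is new or still open speak of the compounds shown alone.

Of the compounds shown here, three built on one shared core have been tested in a functional assay on A498 cells (Homo sapiens) for cytotoxicity; on this read-out lower numbers stand for stronger inhibition of growth and higher numbers for weaker inhibition of growth. Compound 1 `CSc1ccc(C2=C(c3ccc(F)c(C)c3)C(=O)N3CCCC3C2)cc1` gives 300 nM, compound 2 `COc1ccc(C2=C(c3ccc(SC)cc3)CC3CCCN3C2=O)cc1` gives 800 nM and compound 3 `CSc1ccc(C2=C(c3ccc(Br)cc3)C(=O)N3CCCC3C2)cc1` gives 7000 nM. Compound 3 therefore has the highest number of the three, which makes it the weakest growth inhibitor so far.

Compound 4 `CSc1ccc(C2=C(c3ccc(F)cc3)C(=O)N3CCCC3C2)cc1` differs from compound 3 in one place: fluoro in place of bromo on an aromatic carbon. This puts fluoro in place of bromo on an aromatic carbon, para to a large group.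

For the measured compounds named here, two measured steps bear on this change, and both end at the 4-bromophenyl compound. The first is large, a 23-fold higher number from compound 1 to compound 3 (1.37 log units; beyond the scatter), with 4-bromophenyl in place of 4-fluoro-3-methylphenyl. The second is modest, an 8.8-fold higher number from compound 2 to compound 3 (0.94 log units; beyond the scatter), with bromo in place of methoxy. Going by the values given here, neither step isolates fluoro, since the group in compound 1 also carries a methyl, and no measured compound has the 4-fluorophenyl group itself.

Leaving bromo has so far always meant a lower number, so a modest drop is expected in this assay, probably not as large as the first step. The expected size is a 4.7-fold lower number from compound 3 to compound 4 (0.67 log units; beyond the scatter). Compound 4 is estimated at 1500 nM, with an expected range of 400 nM to 5000 nM.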

Compound 4, concentration for 50% growth inhibition: 100 nM
The estimate for compound 4 lay 15-fold (1.18 log units) above the measured number; the whole stated range lies above it.
By their numbers in this assay, from the lowest: compound 4; then compound 1; then compound 2; then compound 3.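

In this assay, for the compounds shown here, the group on this ring, para to a large group, turns out to matter far more than the earlier compounds could show: exchanging bromo for fluoro alone, one heavy atom for one heavy atom with no change in hydrogen-bond donors, acceptors or charge, gives a 70-fold lower number from compound 3 to compound 4 (1.85 log units; beyond the scatter). Fluoro also outperforms methoxy at the same place, with an 8.0-fold lower number from compound 2 to compound 4 (0.90 log units; beyond the scatter), and compound 4 now has the lowest number of the four, with every step to it lying beyond the scatter. The methyl on the fluorinated ring of compound 1 also proves unnecessary for strong growth inhibition here, since hydrogen in its place gives a 3.0-fold lower number from compound 1 to compound 4 (0.48 log units; beyond the scatter).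

Going by these compounds alone, nothing available explains why so small an exchange moves the number so far. Going by these compounds, it remains open where chloro, a nitrile or an amine at this place would fall relative to fluoro and bromo, and whether the advantage of fluoro would persist with something other than the methylthio group on the second ring of the shared core.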